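A Methyl Group on the Cyclopropylsulfonyl Ring

The compounds below may be only part of what the source reports. "The series", "measured", "known", "first", "only" and "open" are said of these compounds alone.

In an ADME assay on the whole organism (Rattus norvegicus) for metabolic stability, at a dose of 1 mg/kg by the intravenous route (on this read-out higher numbers stand for a longer-lived compound and lower numbers for a shorter-lived compound), compound 1 `COc1cnc(O[C@@H]2C[C@H]3C(=O)N[C@]4(C(=O)NS(=O)(=O)C5(C)CC5)C[C@H]4/C=C\CC[C@@H](C)C[C@@H](C)[C@H](NC(=O)OC(C)(C)C(F)(F)F)C(=O)N3C2)c2ccccc12` gives 5.7 h and compound 2 `CC[C@@H]1C[C@H](C)CC/C=C\[C@@H]2C[C@@]2(C(=O)NS(=O)(=O)C2CC2)NC(=O)[C@@H]2C[C@@H](Oc3ncc(OC)c4ccccc34)CN2C(=O)[C@H]1NC(=O)OC(C)(C)C(F)(F)F` gives 4.8 h. Within the data shown here, these two values lie within the scatter of each other, so compound 2 stands level with the only other compound measured so far. Compound 3 `CC[C@@H]1C[C@H](C)CC/C=C\[C@@H]2C[C@@]2(C(=O)NS(=O)(=O)C2(C)CC2)NC(=O)[C@@H]2C[C@@H](Oc3ncc(OC)c4ccccc34)CN2C(=O)[C@H]1NC(=O)OC(C)(C)C(F)(F)F` departs from compound 2 in one place, methyl in place of hydrogen on a saturated ring carbon, which turns cyclopropylsulfonyl into (1-methylcyclopropyl)sulfonyl. Among the measured compounds shown here, no measured step shows what this change does in this assay, so its size cannot be read directly. Starting from compound 2 at 4.8 h, no shift beyond the scatter is expected. The estimated step, a 1.1-fold higher number from compound 2 to compound 3 (0.04 log units; within the scatter), is small and stays within the scatter. Compound 3 is estimated at 5.3 h, with an expected range from 3 h to 9 h.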

Compound 3, half-life: 7.3 h
Beside the measured number, compound 3's estimate is 1.4-fold (0.14 log units) below it; low and high end bracket the measured number.
By their numbers in this assay, from the lowest: compounds 2, 1 and 3 (each within the scatter of the next).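

For this methyl in place of hydrogen on a saturated ring carbon, which turns cyclopropylsulfonyl into (1-methylcyclopropyl)sulfonyl, there is now a measured step in this assay: a 1.5-fold higher number from compound 2 to compound 3 (0.18 log units; within the scatter) stays within the scatter. The second step reads a 1.3-fold higher number from compound 1 to compound 3 (0.11 log units; within the scatter) and also stays within the scatter, so neither single methyl separates these compounds on half-life. Nothing at hand bears on what lies behind these two steps.

On these data alone, whether an ethyl group, a fluorine atom or an amine on that same ring carbon would move the half-life beyond the scatter remains open. So does whether the methyl would behave alike on a different core.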